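Bromo for Methoxy in a Hydroxamate Series

This account rests on a few compounds, and the source may have more. Where it says the series, first, only, none or still open, it means among the compounds named here.

Of the compounds shown here, three have so far been measured in an assay on Sf9 cells for inhibition of protein deacetylase HDAC6 (Homo sapiens), read by fluorescence, with a stated time of 40 min, tested at 100 nM; on this read-out higher numbers stand for more inhibition at the one concentration tested (going by the name of the read-out) and lower numbers for less inhibition. Compound 1 `O=C(NO)c1ccc(NCc2nc(-c3cccs3)nn2-c2ccc(O)cc2)cc1` gives 79.6%, compound 2 `COc1ccc(-c2nc(CNc3ccc(C(=O)NO)cc3)n(-c3ccccc3)n2)cc1` gives 77.6%, and compound 3 `O=C(NO)c1ccc(NCc2nc(-c3ccccc3)nn2-c2ccccc2Cl)cc1` gives 64.6%. Compound 2 thus stands second of the three: its number and that of compound 1 lie within the scatter of each other, while compound 3 lies beyond the scatter below it. Compound 4 `O=C(NO)c1ccc(NCc2nc(-c3ccc(Br)cc3)nn2-c2ccccc2)cc1` has not yet been measured. It differs from compound 2 in one place: bromo in place of methoxy on an aromatic carbon. Within the data shown here, no measured pair shows this same change, so the data give no guide to its size. The step is expected to be small, near the edge of the scatter and leaning slightly downward, a number 5.6 percentage points lower from compound 2 to compound 4 (within the scatter). Compound 4 is therefore estimated to give 72% in this assay, between 55% and 88%.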

Compound 4, a percentage reported as inhibition, at one concentration (the size of the read-out at that concentration, not a potency): 54.7%
Estimate against measurement, compound 4: 17.3 percentage points above; the whole stated range lies above it.
By their numbers in this assay, from the lowest: compounds 4 and 3 (each within the scatter of the next); then compounds 2 and 1 (each within the scatter of the next).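

Among these compounds, replacing 4-methoxyphenyl with 4-bromophenyl is no neutral swap: in this assay the change gives a number 22.9 percentage points lower from compound 2 to compound 4 (beyond the scatter) and provides the first reading of a single change in this set. It shows that inhibition at one concentration is sensitive to the group on this aromatic carbon. Nothing available accounts for the loss.

As far as these compounds go, whether the loss is specific to bromo or follows any removal of methoxy remains open. An amine, a hydroxy or a chloro at this same place on the core of compound 2 would help separate those readings.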